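The compounds below may be only part of what the source reports. "The series", "measured", "known", "first", "only" and "open" are said of these compounds alone.

Measured in an ADME assay on A549 cells (Homo sapiens) for cytotoxicity, read by resazurin assay, with a stated time of 48 h; on this read-out higher numbers stand for lower toxicity in this test and lower numbers for higher toxicity in this test:
- compound 1 `O=C(Nc1ccc(NCc2cccc(C(F)(F)F)c2)cc1Cl)c1cc(Cl)ccc1O`: 13300 nM
- compound 2 `O=C(Nc1ccc(NCc2cc(Cl)cc(Cl)c2)cc1Cl)c1cc(Cl)ccc1O`: 13300 nM

Compound 2 sits at 13300 nM, level with compound 1 at the digits available. The next structure is compound 3 `O=C(Nc1ccc(NCc2ccc(Br)s2)cc1Cl)c1cc(Cl)ccc1O`: 5-bromothiophen-2-yl in place of 3,5-dichlorophenyl on a saturated chain carbon bound to a nitrogen on an aromatic ring. In short, 5-bromothiophen-2-yl takes the place of 3,5-dichlorophenyl, and the shared core stays the same.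

Within the data shown here, only one measured step bears on this change: no change at the digits printed from compound 1 to compound 2 (within the scatter). It exchanged one aromatic group for another at the same place and left this assay flat. That is thin evidence, as it is a single step and no five-membered ring has been measured in this series. Still, no step beyond the scatter is expected, and no direction is favoured. The expected step is a 1.0-fold lower number from compound 2 to compound 3 (0.01 log units; within the scatter).

For compound 3 the estimated value is 13000 nM, with an expected range of 6000 nM to 27000 nM.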

Compound 3, half-maximal cytotoxic concentration: 20700 nM
Compound 3: middle estimate off by 1.6-fold (0.20 log units), on the low side, and the stated range covers the measured number.
By their numbers in this assay, from the lowest: compounds 1, 2 and 3 (each within the scatter of the next).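

In this assay, 5-bromothiophen-2-yl in place of 3,5-dichlorophenyl gives a 1.6-fold higher number from compound 2 to compound 3 (0.19 log units; within the scatter), and the same group in place of 3-(trifluoromethyl)phenyl gives a 1.6-fold higher number from compound 1 to compound 3 (0.19 log units; within the scatter). Compounds 1, 2 and 3 therefore show that a five-membered aromatic ring with 1 hetero atom, carrying bromine, can stand on a saturated chain carbon bound to a nitrogen on an aromatic ring without a step beyond the scatter from either six-membered aromatic ring. Nothing measured here explains the readings at this position.

Still open, going by these compounds, is whether a ring without aromatic character, such as cyclohexyl, or an aromatic ring carrying an amine or a carboxylic acid, would stay level in this assay. A longer chain in place of the saturated chain carbon is equally untested by the compounds shown.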